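A Chloro Substituent on the Phenyl Group of Compound 2

A few compounds are considered here, and "the series" means these few. Any claim that something is new, unique, unknown or untested is made for them only; others in the source may bear on it.

Measured compounds:
compound 1, `CN(C(=O)CCCc1ccccc1)c1nc2ccccc2c(=O)s1`, "not determined" (no result reported) in an assay on mitochondria (strain Sprague-Dawley) for inhibition of Amine oxidase [flavin-containing] B (Rattus norvegicus), read by fluorescence and Amplex Red, with stated times of 30 min and 45 min; on this read-out higher numbers stand for weaker inhibition and lower numbers for stronger inhibition
compound 2, `O=C(CCCc1ccccc1)Nc1nc2ccccc2c(=O)s1`, 186 nM

Going by the values given here, only two compounds have been examined so far. Compound 1 has no reported number in this assay. Among the compounds with values here, compound 2 gives 186 nM in this assay and therefore stands alone as the only measured value; with no second number, no step between measured compounds exists and nothing about the size of any change can be read from the data themselves.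

Compound 3, `O=C(CCCc1cccc(Cl)c1)Nc1nc2ccccc2c(=O)s1`, is the next compound. It differs from compound 2 by chloro in place of hydrogen on an aromatic carbon, the same difference read one bond further out as phenyl to 3-chlorophenyl. Without any measured step to set a scale, the expected change in this assay is small, most likely within the usual scatter, with only a slight lean toward stronger inhibition. Compound 3 is accordingly estimated at 150 nM, with a range from 50 nM to 450 nM. This estimate means an expected step of a 1.2-fold lower number from compound 2 to compound 3 (0.09 log units; within the scatter).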

Compound 3, half-maximal inhibitory concentration: 6880 nM
Compound 3: the middle estimate sits 46-fold (1.66 log units) below what was measured; the whole stated range lies below it.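

The step from phenyl to 3-chlorophenyl brings a 37-fold higher number from compound 2 to compound 3 (1.57 log units; beyond the scatter) in this assay and gives the series its first measured scale. It shows that this aromatic carbon, meta to a large group, does not accept chloro in place of hydrogen without a clear loss of inhibition, so a single added chlorine atom is enough to move the result well beyond the scatter. Nothing measured here bears on the reason for this loss.

On these data alone, whether the loss is particular to chloro or extends to a smaller fluoro or a methoxy group on the same carbon stays open, as does the outcome of chloro on the other carbons of the phenyl ring. As far as these compounds go, compound 1 carries no number, so any step involving it cannot be read, and the effect of a methyl group on the amide nitrogen remains unknown.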